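Swapping one saturated ring for another on the sulfonyl sulfur

The source may hold more compounds than are shown below. What is called first, only, known or untested is meant among the compounds shown, and "the series" means these compounds.

Among the measured compounds shown here, compound 2 `O=C(NCc1ccc(S(=O)(=O)C2CCCOC2)cc1)N1Cc2ccncc2C1` gives 44 nM in an assay on isolated protein for inhibition of Nicotinamide phosphoribosyltransferase (Homo sapiens), read by mass spectrometry, with stated times of 15 min and 30 min (a higher number here means a weaker inhibitor, a lower number a stronger inhibitor), the highest of the two numbers measured so far. For the measured compounds named here, its neighbour compound 1 `O=C(NCc1ccc(S(=O)(=O)c2cc(F)cc(F)c2)cc1)N1Cc2ccncc2C1` gives 7.1 nM in this assay, and the one measured step, a 6.2-fold higher number from compound 1 to compound 2 (0.79 log units; beyond the scatter), arose from replacing an aromatic ring by a saturated one on the sulfonyl sulfur. Compound 3 `CN1CCC(S(=O)(=O)c2ccc(CNC(=O)N3Cc4ccncc4C3)cc2)CC1` differs from compound 2 only in that place: 1-methylpiperidin-4-yl in place of oxan-3-yl on a sulfonyl sulfur. Going by the values given here, no measured step covers an exchange of one saturated six-membered ring for another, so the step from compound 1 to compound 2 offers only indirect guidance, and it does not say which way a change of this kind should run. The expected step of a 1.1-fold higher number from compound 2 to compound 3 (0.06 log units; within the scatter) is therefore one of no change beyond the scatter. Compound 3 is estimated to give 50 nM in this assay, within a range from 15 nM to 170 nM.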

Compound 3, half-maximal inhibitory concentration: 48 nM
For compound 3 the middle estimate is 1.0-fold (0.02 log units) above the measured one; the measured number falls inside the stated range.
By their numbers in this assay, from the lowest: compound 1; then compounds 2 and 3 (each within the scatter of the next).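

On the sulfonyl sulfur, this assay does not separate the two saturated six-membered rings: placing 1-methylpiperidin-4-yl where oxan-3-yl stood, with a ring nitrogen in place of a ring oxygen, gives (a 1.1-fold higher number from compound 2 to compound 3 (0.04 log units; within the scatter)). The 3,5-difluorophenyl group also stays ahead of this second saturated ring (a 6.8-fold higher number from compound 1 to compound 3 (0.83 log units; beyond the scatter)), so the gap first seen with oxan-3-yl is not confined to that one ring. Nothing available explains either result.

The compounds shown leave open whether this tolerance extends to piperidin-4-yl without the methyl group, to a ring carrying a carboxylic acid, or to a smaller ring such as cyclopropyl. They also leave open whether plain phenyl would match 3,5-difluorophenyl, so the aromatic ring and its two fluorines cannot be told apart here.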